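Losing the fluoro-methoxy aryl group from compound 3

The source may hold more compounds than are shown below. What is called first, only, known or untested is meant among the compounds shown, and "the series" means these compounds.

Measured in a functional assay on A549 cells (Homo sapiens) for antiproliferative activity, read by MTT assay, with a stated time of 72 h; on this read-out lower numbers stand for stronger inhibition and higher numbers for weaker inhibition:
Compound 1 `CCOc1ccc(-c2ccc3ncn(-c4cc(OC)c(OC)c(OC)c4)c3c2)cc1`: 8550 nM
Compound 2 `COc1cc(-n2cnc3ccc(-c4ccc(C)cc4F)cc32)cc(OC)c1OC`: > 10000 nM (a limit)
Compound 3 `COc1ccc(-c2ccc3ncn(-c4cc(OC)c(OC)c(OC)c4)c3c2)cc1F`: 1430 nM

Compound 3 gives the lowest number in this assay, at 1430 nM, and its nearest measured neighbour is compound 1, at 8550 nM. For compound 2 the value > 10000 nM is a limit.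

Compound 4 `COc1cc(-n2cnc3ccc(-c4ccccc4)cc32)cc(OC)c1OC` has not yet been measured. It carries phenyl in place of 3-fluoro-4-methoxyphenyl on an aromatic carbon.

Three measured steps change the group at this same place. Two of them end at compound 3: a 6.0-fold lower number from compound 1 to compound 3 (0.78 log units; beyond the scatter) and an at least 6.9-fold lower number from compound 2 to compound 3 (0.84 log units; beyond the scatter). The third, an at least 1.1-fold higher number from compound 1 to compound 2 (0.06 log units; that floor lies within the scatter), separates the two weaker compounds only by a limit. None of them removes a substituent outright, so they guide the estimate only loosely. Since both other groups give clearly higher numbers than 3-fluoro-4-methoxyphenyl, a rise of similar size is expected in this assay, though with wide uncertainty.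

The expected change is a 3.5-fold higher number from compound 3 to compound 4 (0.54 log units; beyond the scatter). For compound 4 the estimated value is 5000 nM, with an expected range from 1500 nM to 15000 nM.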

Compound 4, half-maximal inhibitory concentration: 3060 nM
The estimate for compound 4 lay 1.6-fold (0.21 log units) above the measured number, and the stated range covers the measured number.
By their numbers in this assay, from the lowest: compound 3; then compound 4; then compound 1. At a limit, above all of these: compound 2.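

In this assay, plain phenyl at this position does not fall below the substituted aryl groups, and only 3-fluoro-4-methoxyphenyl gives a lower number: a 2.1-fold higher number from compound 3 to compound 4 (0.33 log units; beyond the scatter). Substituents on this ring therefore do not lower the number as such, and two of the three shown go the other way: hydrogen in place of ethoxy gives a 2.8-fold lower number from compound 1 to compound 4 (0.45 log units; beyond the scatter), and phenyl in place of 2-fluoro-4-methylphenyl gives an at least 3.2-fold lower number from compound 2 to compound 4 (0.51 log units; beyond the scatter). The value for compound 2 is a limit, so this second step is only a floor: the limit of > 10000 nM in this assay, at which 1 of the 4 values shown sits.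

Whether the fluoro or the methoxy group of compound 3 accounts for its lower number remains open, with no phenyl carrying only one of the two among the compounds shown. On these data alone, how an amine or a carboxylic acid on this ring would read also remains open.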